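The source may report more compounds than this note shows. Statements on the series, on what has been measured and on what is new or still open speak of the compounds shown alone.

Compound 1 `CCOC(=O)C12C(=O)OCC=C1COC2c1ccc(F)cc1` gives 22900 nM in a functional assay on HeLa cells (Homo sapiens) for cytotoxicity, read by MTT assay; a lower number here means a stronger inhibitor, a higher number a weaker inhibitor. Compound 3 `CCOC(=O)C12C(=O)OCC=C1COC2c1ccc(Cl)cc1` gives 118000 nM in this assay. Compound 2 `CCOC(=O)C12C(=O)OCC=C1COC2c1cccc(Cl)c1` gives only a limit of this assay, > 1000000 nM, not a number (the limit of > 1000000 nM in this assay, at which 1 of the 3 values shown sits).

Compound 3 thus holds the highest of the two numbers; the nearest comparison is a 5.2-fold higher number from compound 1 to compound 3 (0.71 log units; beyond the scatter). Compound 4 `CCOC(=O)C12C(=O)OCC=C1COC2c1cccs1` differs from compound 3 by thiophen-2-yl in place of 4-chlorophenyl on a saturated ring carbon. The measured steps all alter the aryl group: a 5.2-fold higher number from compound 1 to compound 3 (0.71 log units; beyond the scatter) was modest, an at least 43-fold higher number from compound 1 to compound 2 (1.64 log units; beyond the scatter) large, and an at least 8.4-fold lower number from compound 2 to compound 3 (0.92 log units; beyond the scatter) at least modest. As far as these compounds go, none exchanges the benzene ring for a five-membered ring, so the direction stays open, though the aryl group clearly matters. The expected step is a 2.0-fold lower number from compound 3 to compound 4 (0.29 log units; within the scatter). Compound 4 is estimated at 60000 nM, between 15000 nM and 400000 nM.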

Compound 4, half-maximal inhibitory concentration: 30400 nM
Compound 4: middle estimate off by 2.0-fold (0.30 log units), on the high side; low and high end bracket the measured number.
By their numbers in this assay, from the lowest: compounds 1 and 4 (each within the scatter of the next); then compound 3. At a limit, above all of these: compound 2.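

Replacing the benzene ring at this saturated ring carbon with a five-membered aromatic ring does not cost activity in this assay (a 3.9-fold lower number from compound 3 to compound 4 (0.59 log units; beyond the scatter)). The thiophen-2-yl group matches the 4-fluorophenyl group (a 1.3-fold higher number from compound 1 to compound 4 (0.12 log units; within the scatter)), and the comparison with the 3-chlorophenyl group gives only a bound (an at least 32-fold lower number from compound 2 to compound 4 (1.51 log units; beyond the scatter)). Compound 2 gives a limit, not a number: the limit of > 1000000 nM in this assay, at which 1 of the 4 values shown sits.

As far as these compounds go, whether a ring without sulfur, such as furan-2-yl, would do as well stays open. So does the effect of an amine on the aromatic ring, or of a carboxylic acid in place of the ethoxycarbonyl group.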